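The source may hold more compounds than are shown below. What is called first, only, known or untested is meant among the compounds shown, and "the series" means these compounds.

Three measured compounds share one core and differ only in the group on a saturated ring carbon. Compound 1 `N#CC1=C(N)N(c2ccc(S(N)(=O)=O)cc2)C2=C(CCCC2)C1c1ccccc1O` in a functional assay on Ehrlich cells (Mus musculus) for cytotoxicity, read by trypan blue exclusion, with a stated time of 2 h, tested at 10 ug/mL (a higher number here means a stronger effect of the compound at the concentration tested, a lower number a weaker effect), gives 10%. Compound 2 `COc1ccc(C2C(C#N)=C(N)N(c3ccc(S(N)(=O)=O)cc3)C3=C2CCCC3)cc1` gives 50%, and compound 3 `N#CC1=C(N)N(c2ccc(S(N)(=O)=O)cc2)C2=C(CCCC2)C1c1ccc(Cl)cc1Cl` gives 0%. Compound 3 stands lowest of the three: its nearest neighbour is compound 1, a step within the scatter, a number 10 percentage points lower from compound 1 to compound 3 (within the scatter); its furthest is compound 2, as a number 50 percentage points lower from compound 2 to compound 3 (beyond the scatter) shows, while a number 40 percentage points higher from compound 1 to compound 2 (beyond the scatter) separates the other two.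

Compound 4 `N#CC1=C(N)N(c2ccc(S(N)(=O)=O)cc2)C2=C(CCCC2)C1c1c(O)ccc2ccccc12` is not yet measured. Its change from compound 3 is 2-hydroxynaphthalen-1-yl in place of 2,4-dichlorophenyl on a saturated ring carbon. Among the compounds with values here, two steps bear on it: removing the 2,4-dichlorophenyl in favour of 4-methoxyphenyl gave the large step seen in compound 2, whereas the 2-hydroxyphenyl of compound 1, which like the entering group carries one hydroxyl, sat within the scatter of compound 3. The entering group shares that hydroxyl, so only a modest rise is expected in this assay, about a number 20 percentage points higher from compound 3 to compound 4 (beyond the scatter). Compound 4 is therefore estimated at 20%, between 0% and 50%.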

Compound 4, a percentage reported as activity, at one concentration (the size of the read-out at that concentration, not a potency): 10%
Beside the measured number, compound 4's estimate is 10 percentage points above it; measured number inside the range.
By their numbers in this assay, from the lowest: compounds 3, 1 and 4 (each within the scatter of the next); then compound 2.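

In this assay, moving from one aromatic ring to the two rings of 2-hydroxynaphthalen-1-yl on this saturated ring carbon gives no clear gain: no change at the digits printed from compound 1 to compound 4 (within the scatter), and a number 10 percentage points higher from compound 3 to compound 4 (within the scatter). The larger group therefore does not reach the level of the 4-methoxyphenyl, as a number 40 percentage points lower from compound 2 to compound 4 (beyond the scatter). Among the four compounds, only compound 2 stands clear of the others, while the 2-hydroxyphenyl, 2-hydroxynaphthalen-1-yl and 2,4-dichlorophenyl groups cannot be told apart in this assay.

Going by these compounds, it remains open whether a 4-aminophenyl or 4-carboxyphenyl group on this carbon would match the 4-methoxyphenyl, which would help show whether the methoxy group itself matters. Nothing measured here explains why compound 2 stands apart.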